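Acyl extension on the anilide of compound 1

A few compounds are considered here, and "the series" means these few. Any claim that something is new, unique, unknown or untested is made for them only; others in the source may bear on it.

Compound 1 `O=CNc1ccc(C2=NNC(=O)CC2)cc1` is the only anchor with a finite number. In a functional assay for inhibition, with Homo sapiens as the target (a higher number here means that more compound is needed for the effect, a lower number that less compound is needed), compound 1 gives 3.74 ug/mL. Compound 2 `CC(=O)Nc1ccc(C2=NN(C)C(=O)CC2)cc1` is reported in this assay at > 46.4 ug/mL, which is a limit of the assay and not a number. Compound 2 differs from compound 1 in more than one place, so no single step can be read from that pair. Going by the values given here, the only further evidence in this assay is the limit of > 46.4 ug/mL in this assay, at which 1 of the 2 values shown sits.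

Compound 3 `CC(Cl)C(=O)Nc1ccc(C2=NNC(=O)CC2)cc1` carries the change (1-chloroethyl in place of hydrogen on a carbonyl carbon), so the amide hydrogen of compound 1 is kept while the formyl grows to the ((1-chloroethyl)carbonyl)amino group. Among the compounds with values here, no measured step of this kind exists in the set, and the limit of compound 2 cannot be tied to any one change. The step expected in this assay, a 1.6-fold higher number from compound 1 to compound 3 (0.21 log units; within the scatter), is judged small, tending toward more compound being needed, and possibly not beyond the scatter. The value expected for compound 3 in this assay is 6 ug/mL, with a range from 1.5 ug/mL to 25 ug/mL.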

Compound 3, half-maximal effective concentration: 0.45 ug/mL
Beside the measured number, compound 3's estimate is 13-fold (1.12 log units) above it, and the stated range ends above it.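

The carbonyl carbon whose other neighbour is the amide-type nitrogen accepts more than a hydrogen in this assay: placing 1-chloroethyl there gives an 8.3-fold lower number from compound 1 to compound 3 (0.92 log units; beyond the scatter). Going by these compounds alone, this is the first step that can be read at a single place, and it shows that growing formyl to (1-chloroethyl)carbonyl, with the amide hydrogen kept, goes with less compound being needed rather than with a loss of effect. Nothing measured here bears on the cause of this step, and one compound pair cannot establish a pattern for this position.

Compound 2 stands at > 46.4 ug/mL in this assay, which is a limit of the assay and not a number. Compound 2 differs from compound 1 and from compound 3 in more than one place. Its comparisons with these two compounds cannot be read as steps. On these data alone, whether the step belongs to the chlorine or to the added carbons stays open, as does how a plain ethyl, a 1-aminoethyl or a longer chain on the same carbonyl carbon would read.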